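Thiophen-2-yl to Propyl on the Hydrazide Chain

The source may hold more compounds than are shown below. What is called first, only, known or untested is meant among the compounds shown, and "the series" means these compounds.

Measured in an assay for inhibition of Polyunsaturated fatty acid lipoxygenase ALOX15 (Homo sapiens), with a stated time of 8 min; on this read-out higher numbers stand for weaker inhibition and lower numbers for stronger inhibition:
Compound 1 `CCOC(=O)c1[nH]c2cc(Cl)ccc2c1/C=N/NC(=O)Cc1ccccc1` gives only the assay limit, > 10000 nM.
Compound 2 `CCOC(=O)c1[nH]c2cc(Cl)ccc2c1/C=N/NC(=O)Cc1cccs1` gives only the assay limit, > 10000 nM.

Compound 2 stands, like compound 1, at the limit of this assay, so no number for it is known, only that its inhibition is weaker than the assay can resolve. Among the measured compounds shown here, the one measured step, a step that the two limits leave unreadable from compound 1 to compound 2, lies between two limits and its size cannot be read; both values sit at the limit of > 10000 nM in this assay, at which 2 of the 2 values shown sit.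

Compound 3 `CCCCC(=O)N/N=C/c1c(C(=O)OCC)[nH]c2cc(Cl)ccc12` differs from compound 2 by propyl in place of thiophen-2-yl on a saturated chain carbon bound to a carbonyl carbon. For the measured compounds named here, the only step measured at this position, from phenyl to thiophen-2-yl, gave no readable change, so the data offer no direction for the propyl. With both neighbours at the limit, compound 3 is expected to remain there too, and the step that the limit leaves unreadable from compound 2 to compound 3 is estimated to be none beyond the scatter. Compound 3 is therefore estimated at 20000 nM in this assay, within a range from 5000 nM to 80000 nM, with the likeliest outcome that only a limit is reported again.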

Compound 3, half-maximal inhibitory concentration: > 10000 nM
Compound 3 gave a limit, no number; the forecaster's own chance of this, stated with the estimate: 85%; the middle value does not contradict the limit.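

In this assay compound 3 gives only a limit, > 10000 nM. Among the compounds shown here, no step among compound 1, compound 2 and compound 3 can therefore be read: the limit of > 10000 nM in this assay, at which 3 of the 3 values shown sit. The compounds shown leave open whether any group on a saturated chain carbon bound to a carbonyl carbon can bring a measurable value in this assay.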